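A few compounds are considered here, and "the series" means these few. Any claim that something is new, unique, unknown or untested is made for them only; others in the source may bear on it.

Compound 1 `O=C1O[C@@H](CO)CN1c1ccc(-n2cc(-c3ccccn3)cn2)c(F)c1`, compound 2 `O=C1CSC(=O)N1C[C@H]1CN(c2ccc(-n3cc(-c4ccccn4)cn3)c(F)c2)C(=O)O1`, compound 3 `COC(=O)NC[C@H]1CN(c2ccc(-n3cc(-c4ccccn4)cn3)c(F)c2)C(=O)O1`.

In an ADME assay on L02 cells (Homo sapiens) for cytotoxicity, read by MTT assay, with a stated time of 48 h (on this read-out higher numbers stand for weaker inhibition and lower numbers for stronger inhibition), compound 1 gives 59 ug/mL. Compound 3 gives 71 ug/mL in this assay. Going by the values given here, for compound 2 this assay reports only a limit, > 400 ug/mL, so compound 2 stands apart from the other two as the one value sitting at the limit of > 400 ug/mL in this assay, at which 1 of the 3 values shown sits. The step toward compound 4 `CCNC(=O)NC[C@H]1CN(c2ccc(-n3cc(-c4ccccn4)cn3)c(F)c2)C(=O)O1` changes one group on the shared core: (ethylcarbamoyl)amino in place of 2,4-dioxo-1,3-thiazolidin-3-yl on a saturated chain carbon bound to a saturated ring carbon. Among the compounds with values here, two measured steps bear on this change. The step of an at least 5.6-fold lower number from compound 2 to compound 3 (0.75 log units; beyond the scatter) exchanges the same leaving group for another group without a ring on the same chain carbon, and the step of an at least 6.7-fold higher number from compound 1 to compound 2 (0.83 log units; beyond the scatter) shows the ring-bearing group alone carrying the high number. The step of a 1.2-fold higher number from compound 1 to compound 3 (0.08 log units; within the scatter) shows that a group without a ring on that carbon leaves the number where the hydroxy parent sits. Compound 4 is therefore expected to show a step of an at least 4.4-fold lower number from compound 2 to compound 4 (0.64 log units; beyond the scatter). The estimate for compound 4 in this assay is 90 ug/mL, with a range from 40 ug/mL to 300 ug/mL.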

Compound 4, half-maximal inhibitory concentration: > 400 ug/mL
Compound 4 gave a limit, no number; the forecaster's own chance of this, stated with the estimate: 20%; at least 4.4-fold (0.64 log units) between middle value and limit.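

Compound 4, whose (ethylcarbamoyl)amino group has no ring, ends at a limit in this assay, and that limit is not a number, the same outcome as for compound 2: the limit of > 400 ug/mL in this assay, at which 2 of the 4 values shown sit.

A ring on this saturated chain carbon is therefore not required for the high number, and a group without a ring does not always stay with the hydroxy parent, as an at least 6.7-fold higher number from compound 1 to compound 4 (0.83 log units; beyond the scatter) shows. Ethylamino in place of methoxy on a carbonyl carbon is enough on its own to separate two groups without a ring, giving an at least 5.6-fold higher number from compound 3 to compound 4 (0.75 log units; beyond the scatter).

The step between compound 2 and compound 4 cannot be read, since both values are limits. From the compounds shown here alone, whether a plain amine or a longer chain in place of ethylamino on that carbonyl carbon would also reach the limit stays open.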